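A Biaryl Replacement on a Weak Antiproliferative Series

This account rests on a few compounds, and the source may have more. Where it says the series, first, only, none or still open, it means among the compounds named here.

Compound 2 `COc1ccc(Cn2ncc(NCCOc3ccccc3OC)c(Cl)c2=O)cc1OC` is one of three compounds examined in a functional assay on SH-SY5Y cells (Homo sapiens) for antiproliferative activity, read by MTT assay, with a stated time of 48 h; on this read-out higher numbers stand for weaker inhibition of growth and lower numbers for stronger inhibition of growth. In this assay compound 2 gives 33100 nM, the higher of the two numbers the series provides. Compound 3 `COc1ccccc1OCCNc1ccc(=O)n(Cc2ccc(OC(F)F)c(OC3CCCC3)c2)n1`, built on a different core, gives 9300 nM in this assay, and the gap between compound 3 and compound 2 lies beyond the scatter of this kind of measurement. Compound 1 `COc1ccccc1OCCNc1cnn(Cc2ccc(OC(F)F)c(OCC3CC3)c2)c(=O)c1Cl` shares the core of compound 2. In this assay compound 1 gives > 100000 nM, which is a limit of the assay and not a number (the limit of > 100000 nM in this assay, at which 1 of the 3 values shown sits).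

Compound 4 `COc1ccccc1OCCNc1cnn(Cc2ccc(OC)c(-c3cccc(Cl)c3)c2)c(=O)c1Cl` keeps the core of compound 2 and differs from it in one place: 3-chlorophenyl in place of methoxy on an aromatic carbon. Among the measured compounds shown here, no step between measured compounds touches this kind of change, and the two compounds that share this core offer one number and one limit, nothing more. The step from compound 2 to compound 4 is expected to be a 1.7-fold lower number from compound 2 to compound 4 (0.22 log units; within the scatter), a modest move that could fall within the scatter on either side. Compound 4 is estimated at 20000 nM in this assay, with a plausible range from 5000 nM to 80000 nM.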

Compound 4, concentration for 50% growth inhibition: > 100000 nM
Compound 4: a limit, no number; the forecaster's own chance of this, stated with the estimate: 20%; middle value at least 5.0-fold (0.69 log units) from the limit.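

Among the compounds shown here, putting 3-chlorophenyl in place of methoxy, on an aromatic carbon ortho to a methoxy group, gives the first step that bears on this position, and it goes against growth inhibition: an at least 3.0-fold higher number from compound 2 to compound 4 (0.48 log units; beyond the scatter). In this assay compound 4 gives > 100000 nM, which is a limit of the assay and not a number. The larger group, which brings a six-membered aromatic ring of carbon only to this carbon, therefore brought no gain here, and the step is beyond the scatter, which the earlier compounds could not show for this change, and the values shown now gather at the top of the range that can be read: the limit of > 100000 nM in this assay, at which 2 of the 4 values shown sit.

How far compound 4 lies past that limit stays unknown, as does whether the loss follows the added ring or its chlorine, since a plain phenyl ring is not among the compounds shown. Also open, as far as these compounds go, is what a smaller group on this carbon, such as a fluorine atom or an ethoxy chain, or a group of another kind, such as an amine, would do to growth inhibition.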